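The source may report more compounds than this note shows. Statements on the series, on what has been measured and on what is new or still open speak of the compounds shown alone.

The three measured compounds share one core and differ only in the group attached to the ring nitrogen. Compound 1 `O=C(CCCC1CCN(C(=O)c2ccccc2)CC1)c1ncco1` carries a benzoyl group there, and in an assay on isolated protein for inhibition of Fatty-acid amide hydrolase 1 (Homo sapiens) (on this read-out lower numbers stand for stronger inhibition and higher numbers for weaker inhibition), compound 1 gives 77 nM. Compound 2 `O=C(CCCC1CCN(C(=O)C2CCCCC2)CC1)c1ncco1` has a cyclohexyl ring on the same carbonyl carbon, and in this assay compound 2 gives 45 nM; the step of a 1.7-fold lower number from compound 1 to compound 2 (0.23 log units; within the scatter) is small. Compound 3 `CC(C)OC(=O)N1CCC(CCCC(=O)c2ncco2)CC1` carries an isopropoxycarbonyl group, and in this assay compound 3 gives 4 nM, the lowest of the three numbers: the steps of a 19-fold lower number from compound 1 to compound 3 (1.28 log units; beyond the scatter) and an 11-fold lower number from compound 2 to compound 3 (1.05 log units; beyond the scatter) are both large.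

Compound 4 `Cc1cccc(CN2CCC(CCCC(=O)c3ncco3)CC2)c1` takes a different route: 3-methylbenzyl in place of isopropoxycarbonyl on an amine nitrogen in a ring. Both measured steps that reach compound 3 swap one group for another on a carbonyl carbon while keeping the carbonyl in place; neither step removes it. Among the measured compounds shown here, the change to compound 4 takes away the whole isopropoxycarbonyl group, carbonyl included, so no measured step bears on it directly. With every measured compound carrying a carbonyl on that nitrogen and compound 3 at the low end, a step to a higher number is expected, of a size given by a 130-fold higher number from compound 3 to compound 4 (2.10 log units; beyond the scatter), though with wide uncertainty. The estimate for compound 4 in this assay is 500 nM, with a range from 40 nM to 6000 nM.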

Compound 4, half-maximal inhibitory concentration: 90 nM
Beside the measured number, compound 4's estimate is 5.6-fold (0.74 log units) above it; the range from low to high includes it.
By their numbers in this assay, from the lowest: compound 3; then compounds 2, 1 and 4 (each within the scatter of the next).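

Among the compounds shown here, compound 4 is the first compound here without a carbonyl on the amine nitrogen in the ring, and in this assay replacing isopropoxycarbonyl with 3-methylbenzyl gives a large step, a 23-fold higher number from compound 3 to compound 4 (1.35 log units; beyond the scatter), so this position does respond to the swap. Set against the other two groups, the steps are within the scatter: cyclohexylcarbonyl to 3-methylbenzyl gives a 2.0-fold higher number from compound 2 to compound 4 (0.30 log units; within the scatter), and benzoyl to 3-methylbenzyl gives a 1.2-fold higher number from compound 1 to compound 4 (0.07 log units; within the scatter), which shows that among these four compounds a carbonyl on this nitrogen does not by itself set the number, since only the isopropoxycarbonyl compound stands apart from the others. Nothing available here accounts for why isopropoxycarbonyl stands apart or why the three other groups sit so close together.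

The compounds shown leave open whether a close relative of isopropoxycarbonyl, such as ethoxycarbonyl or tert-butoxycarbonyl, would stay at the low end of the numbers or whether the isopropyl part matters. They also leave open whether plain benzyl, without the methyl group, or a urea on the same nitrogen would fall with compound 4 or with compound 3.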